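This account rests on a few compounds, and the source may have more. Where it says the series, first, only, none or still open, it means among the compounds named here.

Measured so far in a functional assay on HT cells (Homo sapiens) for antiproliferative activity, read by fluorescence, with a stated time of 72 h; a higher number here means a weaker inhibitor of growth, a lower number a stronger inhibitor of growth:
compound 1 `CC(C)c1n[nH]c2c(NCc3ccc(-c4ccccn4)cc3)nc(SCC(O)C(F)(F)F)nc12` gives 690 nM;
compound 2 `CSc1nc(NCc2ccc(-c3ccccn3)cc2)c2[nH]nc(C(C)C)c2n1` gives 783 nM;
compound 3 `CC(C)c1n[nH]c2c(NCc3ccc(-c4ccccn4)cc3)nc(SCC3CNC(=O)O3)nc12` gives 80 nM.

Compound 1 stands second highest of these three numbers, with compound 2 nearest and compound 3 furthest. Compound 4 `C=CCSc1nc(NCc2ccc(-c3ccccn3)cc2)c2[nH]nc(C(C)C)c2n1` differs from compound 1 by vinyl in place of 2,2,2-trifluoro-1-hydroxyethyl on a saturated chain carbon bound to a sulfur. The step that bears most on this is a 1.1-fold higher number from compound 1 to compound 2 (0.05 log units; within the scatter), where hydrogen took the place of the same leaving group. The ring replacement, an 8.6-fold lower number from compound 1 to compound 3 (0.94 log units; beyond the scatter) and a 9.8-fold lower number from compound 2 to compound 3 (0.99 log units; beyond the scatter), lowered the number, but vinyl brings no ring and no donor or acceptor. A step within the scatter is therefore expected, a 1.1-fold higher number from compound 1 to compound 4 (0.04 log units; within the scatter). Compound 4 is estimated at 750 nM, between 350 nM and 1600 nM.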

Compound 4, concentration for 50% growth inhibition: 1010 nM
Estimate against measurement, compound 4: 1.3-fold (0.13 log units) below; measured number inside the range.
By their numbers in this assay, from the lowest: compound 3; then compounds 1, 2 and 4 (each within the scatter of the next).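

In this assay, a 1.5-fold higher number from compound 1 to compound 4 (0.17 log units; within the scatter) and a 1.3-fold higher number from compound 2 to compound 4 (0.11 log units; within the scatter) both stay within the scatter, so compound 1, compound 2 and compound 4 sit at one level, although the allyl chain has no hydrogen-bond donor or acceptor. Only the 2-oxo-1,3-oxazolidin-5-yl group stands apart, with a 13-fold higher number from compound 3 to compound 4 (1.10 log units; beyond the scatter) as a large step. No evidence given here explains these results.

From the compounds shown here alone, whether an amine, a carboxylic acid or a longer chain at this place would match compound 3 remains open. So does whether the ring of compound 3 matters, or only its carbonyl and amide hydrogen.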